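A few compounds are considered here, and "the series" means these few. Any claim that something is new, unique, unknown or untested is made for them only; others in the source may bear on it.

Measured so far in an ADME assay on MDBK cells (Bos taurus) for cytotoxicity; a higher number here means that more compound is tolerated, a lower number that less compound is tolerated:
- compound 1 `Cc1ccc(Cn2ccc3nc(-c4ccccc4)nc-3c2)cc1`: > 100000 nM (a limit of the assay, not a number)
- compound 2 `Ic1ccc(Cn2ccc3nc(-c4ccccc4)nc-3c2)cc1`: 22000 nM
- compound 3 `Clc1ccc(Cn2ccc3nc(-c4ccccc4)nc-3c2)cc1Cl`: 71000 nM

Of the two actual numbers, compound 3 holds the higher, at 71000 nM. The gap is a 3.2-fold higher number from compound 2 to compound 3 (0.51 log units; beyond the scatter).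

Compound 4 `CC(C)=CCn1ccc2nc(-c3ccccc3)nc-2c1` differs by 2-methylprop-1-en-1-yl in place of 3,4-dichlorophenyl on a saturated chain carbon bound to an aromatic nitrogen. All measured steps keep the phenyl ring, so they bear only loosely on this change: an at least 4.5-fold lower number from compound 1 to compound 2 (0.65 log units; beyond the scatter) lies beyond the scatter, while the floor of an at least 1.4-fold lower number from compound 1 to compound 3 (0.14 log units; that floor lies within the scatter) lies within it. Compound 4 carries no chlorine or iodine, and neither does compound 1, whose > 100000 nM is a limit.

The expected change is small, at most slightly upward: a 1.3-fold higher number from compound 3 to compound 4 (0.10 log units; within the scatter). For compound 4 the estimated value is 90000 nM, with an expected range of 35000 nM to 200000 nM.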

Compound 4, half-maximal cytotoxic concentration: > 100000 nM
Compound 4 was reported as a limit; the forecaster's own chance of this, stated with the estimate: 45%; at least 1.1-fold (0.04 log units) between middle value and limit.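

In this assay compound 4 gives > 100000 nM, which is a limit of the assay. With no ring in the 2-methylprop-1-en-1-yl group, the result still sits at that limit, so a phenyl ring on this saturated chain carbon is not required to reach it: the limit of > 100000 nM in this assay, at which 2 of the 4 values shown sit. Replacing the aryl groups gives an at least 4.5-fold higher number from compound 2 to compound 4 (0.65 log units; beyond the scatter) and also an at least 1.4-fold higher number from compound 3 to compound 4 (0.14 log units; that floor lies within the scatter); the step involving compound 1 cannot be read.

Still open, going by these compounds, is how an amine or a carboxylic acid on a longer chain at this position would stand in this assay.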